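A few compounds are considered here, and "the series" means these few. Any claim that something is new, unique, unknown or untested is made for them only; others in the source may bear on it.

Of the compounds shown here, two built on a shared core have been tested in a functional assay for inhibition of sodium/hydrogen exchanger (Oryctolagus cuniculus); a lower number here means a stronger inhibitor, a higher number a weaker inhibitor. Compound 1 `CCc1cc(OC)c(S(C)(=O)=O)cc1C(=O)N=C(N)N` gives 30 nM in this assay. Compound 2 `CS(=O)(=O)c1cc(C(=O)N=C(N)N)c(Cl)cc1Oc1cccnc1` gives 52 nM in this assay. Of these two numbers, compound 2 has the higher one, with compound 1 the nearer, yet the gap between them lies within the usual scatter of repeated measurements, so the two cannot be told apart on these data. Compound 3 `CCc1cc(Oc2cccnc2)c(S(C)(=O)=O)cc1C(=O)N=C(N)N` has not yet been measured. It differs from compound 2 in one place: ethyl in place of chloro on an aromatic carbon. Among the measured compounds shown here, no pair among the measured compounds differs only in this way, so there is no measured step to lean on; compound 1 also carries an ethyl, but it differs from compound 2 in a second place too, so its value sets no direct precedent. A small change like this is expected to move the number little: the step of a 1.3-fold lower number from compound 2 to compound 3 (0.11 log units; within the scatter) is expected to stay within the scatter, with no clear direction. Compound 3 is expected to give about 40 nM in this assay, with a likely range from 13 nM to 120 nM.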

Compound 3, half-maximal inhibitory concentration: 27 nM
Beside the measured number, compound 3's estimate is 1.5-fold (0.17 log units) above it, within the range that was stated.
By their numbers in this assay, from the lowest: compounds 3, 1 and 2 (each within the scatter of the next).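

In this assay, the swap of chloro for ethyl on this aromatic carbon, para to the methylsulfonyl group, now has a measured step of its own, a 1.9-fold lower number from compound 2 to compound 3 (0.28 log units; within the scatter), so with a (pyridin-3-yl)oxy group in the compound, these data cannot tell the two groups apart at this position. Among the compounds shown here, the same compound also gives the first one-place comparison on the oxygen on the aromatic ring, where pyridin-3-yl in place of methyl gives a 1.1-fold lower number from compound 1 to compound 3 (0.05 log units; within the scatter), so with ethyl kept on the aromatic carbon, those two groups cannot be told apart either. Nothing measured here offers a reason why either swap leaves the number within the scatter.

Going by these compounds, each swap rests on a single pair, so it remains open whether chloro and ethyl would also match with methyl rather than pyridin-3-yl on the oxygen. On these data alone, it also remains open whether a longer chain such as butyl, an amine or a carboxylic acid on this aromatic carbon would keep the number in the same range or move it clearly.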